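Iodo in place of phenyl on the shared core

The compounds below may be only part of what the source reports. "The series", "measured", "known", "first", "only" and "open" are said of these compounds alone.

For the measured compounds named here, compound 1 `CCCCCCNC(=O)n1cc(OC)c(=O)[nH]c1=O` gives 1100 nM in an assay on HEK293 cells for inhibition of acid ceramidase (Rattus norvegicus), read by LC-MS, with a stated time of 30 min (a higher number here means a weaker inhibitor, a lower number a stronger inhibitor), while compound 2 `CCCCCCNC(=O)n1cc(-c2ccccc2)c(=O)[nH]c1=O` gives 177 nM in this assay, the lowest of the two numbers measured; the only measured step is a 6.2-fold lower number from compound 1 to compound 2 (0.79 log units; beyond the scatter). Compound 3 `CCCCCCNC(=O)n1cc(I)c(=O)[nH]c1=O` differs from compound 2 by iodo in place of phenyl on an aromatic carbon. That single step speaks to phenyl entering against methoxy, not against iodo, so it bears only partly on this change; with phenyl leaving, a rise in the number is expected, a 2.3-fold higher number from compound 2 to compound 3 (0.35 log units; beyond the scatter), but smaller than the measured step. Compound 3 is therefore estimated at 400 nM, within 120 nM to 1500 nM.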

Compound 3, half-maximal inhibitory concentration: 147 nM
Estimate against measurement, compound 3: 2.7-fold (0.43 log units) above; the range from low to high includes it.
By their numbers in this assay, from the lowest: compounds 3 and 2 (each within the scatter of the next); then compound 1.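

Iodo in place of phenyl gives a 1.2-fold lower number from compound 2 to compound 3 (0.08 log units; within the scatter) in this assay, so on this aromatic carbon a single iodine atom serves as well as a six-carbon aromatic ring, and a ring is not needed to reach this level. Against methoxy, iodo gives a 7.5-fold lower number from compound 1 to compound 3 (0.87 log units; beyond the scatter), so phenyl is not alone in standing apart from methoxy. No measured evidence bears on why these groups compare as they do.

Open, from the compounds shown here alone, is whether chloro, fluoro, an amine or a carboxylic acid on this carbon would hold the number. Also open, going by these compounds, is whether a longer chain would change the picture.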